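The compounds below may be only part of what the source reports. "The series", "measured", "known", "first", "only" and "open" are said of these compounds alone.

Compound 1 `O=c1ccc2cc(OCc3cn(-c4ccccc4)nn3)ccc2o1` and compound 2 `COc1ccc(-n2cc(COc3ccc4oc(=O)ccc4c3)nn2)cc1` share one core and differ at a single aromatic carbon. In a functional assay on HL-60 cells (Homo sapiens) for cytotoxicity, read by MTT assay, with a stated time of 48 h (a lower number here means a stronger inhibitor, a higher number a weaker inhibitor), compound 1 gives 41600 nM, and compound 2 gives 46400 nM. These two numbers sit close together: the change a 1.1-fold higher number from compound 1 to compound 2 (0.05 log units; within the scatter) stays within the usual scatter, so compound 2 stands level with compound 1 rather than apart from it. Compound 3 `CC(=O)Nc1ccc(-n2cc(COc3ccc4oc(=O)ccc4c3)nn2)cc1` is the next variation on compound 2: acetamido in place of methoxy on an aromatic carbon. Among the measured compounds shown here, no measured pair shows acetamido taking the place of methoxy, so the only step that bears on this position is the one adding methoxy to hydrogen, a 1.1-fold higher number from compound 1 to compound 2 (0.05 log units; within the scatter), which was small. On that basis the number in this assay is expected to move little, if at all, with an expected step of a 1.0-fold lower number from compound 2 to compound 3 (0.01 log units; within the scatter). Compound 3 is therefore estimated at 45000 nM, within a range from 15000 nM to 130000 nM.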

Compound 3, half-maximal inhibitory concentration: 40400 nM
Compound 3: middle estimate off by 1.1-fold (0.05 log units), on the high side, and the stated range covers the measured number.
By their numbers in this assay, from the lowest: compounds 3, 1 and 2 (each within the scatter of the next).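

In this assay, this position has now carried hydrogen, methoxy and acetamido, and the numbers stay level: the new group gives a 1.1-fold lower number from compound 2 to compound 3 (0.06 log units; within the scatter), and set against hydrogen it gives a 1.0-fold lower number from compound 1 to compound 3 (0.01 log units; within the scatter). Acetamido is the larger group, with more heavy atoms than methoxy, a double bond outside aromatic rings and a hydrogen-bond donor, yet none of these differences separates compound 3 from the other two here. Nothing measured alongside these numbers accounts for this flat result.

From the compounds shown here alone, it remains open whether an amine or a carboxylic acid on this aromatic carbon, or a longer chain in place of the acetyl part of acetamido, would also leave the number level. Whether changes elsewhere on the shared core would move it is also unknown.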